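Two fluorines in place of one bromine on the ketone aryl ring

A few compounds are considered here, and "the series" means these few. Any claim that something is new, unique, unknown or untested is made for them only; others in the source may bear on it.

Measured so far:
Compound 1, `COc1cc(-c2nnc3n2NC(c2ccco2)C(C(=O)c2ccc(Br)cc2)S3)cc(OC)c1OC`: > 100000 nM
Compound 2, `COc1cc(-c2nnc3n2NC(c2cccs2)C(C(=O)c2ccc(C)cc2)S3)cc(OC)c1OC`: 3700 nM
Compound 3, `COc1ccc(C(=O)C2Sc3nnc(-c4cc(OC)c(OC)c(OC)c4)n3NC2c2cccs2)cc1`: 68000 nM

All three compounds share a common core and were tested in a functional assay on HepG2 cells (Homo sapiens) for cytotoxicity, read by MTT assay, with a stated time of 48 h; on this read-out lower numbers stand for stronger inhibition and higher numbers for weaker inhibition. Compound 2 gives 3700 nM, and compound 3 gives 68000 nM, a change that is an 18-fold higher number from compound 2 to compound 3 (1.26 log units; beyond the scatter). For compound 1 the result is only a limit, > 100000 nM, as noted by the limit of > 100000 nM in this assay, at which 1 of the 3 values shown sits, so its true value is not known beyond that bound.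

Compound 4, `COc1cc(-c2nnc3n2NC(c2ccco2)C(C(=O)c2ccc(F)c(F)c2)S3)cc(OC)c1OC`, has not yet been measured. It differs from compound 1 by 3,4-difluorophenyl in place of 4-bromophenyl on a carbonyl carbon. Among the measured compounds shown here, no measured step covers this exact change; the one measured step, an 18-fold higher number from compound 2 to compound 3 (1.26 log units; beyond the scatter), concerns a different substituent swap and shows only that a small change on the ring attached to the carbonyl can move the number a great deal in this assay. With compound 1 sitting at a limit, there is no firm starting number, and a sizeable chance remains that compound 4 will also report only a limit.

Compound 4 is therefore expected to stay weak, at an estimated 100000 nM with a range of 20000 nM to 300000 nM, which would be a number no higher from compound 1 to compound 4 (the limit leaves the size open).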

Compound 4, half-maximal inhibitory concentration: 52400 nM
The estimate for compound 4 lay 1.9-fold (0.28 log units) above the measured number, within the range that was stated.
By their numbers in this assay, from the lowest: compound 2; then compounds 4 and 3 (each within the scatter of the next). At a limit, above all of these: compound 1.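

In this assay, putting 3,4-difluorophenyl in place of 4-bromophenyl on the carbonyl carbon gives an at least 1.9-fold lower number from compound 1 to compound 4 (0.28 log units; that floor lies within the scatter). What is new is that, with the rest of the structure kept as in compound 1, a change in this one group yields a measured number for compound 4 rather than a limit. The true size of the step remains unknown, as it could be small or large, because compound 1 gives only a limit: the limit of > 100000 nM in this assay, at which 1 of the 4 values shown sits.

The compounds shown leave open which part of the change matters, since a single fluorine or a lone chlorine on that ring would be needed to separate the effect of the two fluorines from the loss of the bromine. Also open, from the compounds shown here alone, is how an amine or a carboxylic acid on that ring would read in this assay.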